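One Methoxy Group, Two Linker Lengths

This account rests on a few compounds, and the source may have more. Where it says the series, first, only, none or still open, it means among the compounds named here.

Compound 1 `O=C(CCCCC1CCSS1)NCc1cn(CCCOc2ccc3cc(-c4ccccc4)c(=O)oc3c2)nn1` and compound 3 `O=C(CCCCC1CCSS1)NCc1cn(CCCCOc2ccc3cc(-c4ccccc4)c(=O)oc3c2)nn1` share the same kind of core; the difference between the two cores is not broken down here. In a functional assay on PC-12 cells (Rattus norvegicus) for cytotoxicity, read by MTT assay, with stated times of 3 h and 2 h, tested at 50 uM (a higher number here means a stronger effect of the compound at the concentration tested, a lower number a weaker effect), compound 1 gives 23.1%, and in the same assay compound 3 gives 20.5%, so the two numbers lie within the scatter of each other and no order between them can be read.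

Compound 2 `COc1ccc(-c2cc3ccc(OCCCn4cc(CNC(=O)CCCCC5CCSS5)nn4)cc3oc2=O)cc1` arises from compound 1 by one change: methoxy in place of hydrogen on an aromatic carbon. In this assay compound 2 gives 65.7%. The measured step is a number 42.6 percentage points higher from compound 1 to compound 2 (beyond the scatter), which is large and well beyond the scatter.

Compound 4 `COc1ccc(-c2cc3ccc(OCCCCn4cc(CNC(=O)CCCCC5CCSS5)nn4)cc3oc2=O)cc1` has not yet been measured. It stands to compound 3 exactly as compound 2 stands to compound 1, the change being (methoxy in place of hydrogen on an aromatic carbon). The place words for both changes agree word for word, so it is the same change, occurring twice among the compounds shown, once measured and once not.

The expectation for compound 4 therefore rests on a single observed step. Going by the values given here, compound 3 to compound 4 is estimated to move by a number 41.5 percentage points higher from compound 3 to compound 4 (beyond the scatter), taken to be of about the same size as the earlier one because a number 42.6 percentage points higher from compound 1 to compound 2 (beyond the scatter) is the only instance of this change with a number attached, and the two starting points lie within the scatter of each other. Compound 4 is thus expected to give 62%, most likely between 42% and 80%.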

Compound 4, a percentage reported as activity, at one concentration (the size of the read-out at that concentration, not a potency): 55.3%
Beside the measured number, compound 4's estimate is 6.7 percentage points above it; the range from low to high includes it.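

In this assay the change from phenyl to 4-methoxyphenyl now has two readings, and the new one, a number 34.8 percentage points higher from compound 3 to compound 4 (beyond the scatter), is large like the first. Set side by side, the two steps cannot be told apart, so the change carried over from the core of compound 1 to the core of compound 3 without a measurable difference in size: the same change on two cores in this assay, a number 42.6 percentage points higher (beyond the scatter) from compound 1 to compound 2 and a number 34.8 percentage points higher (beyond the scatter) from compound 3 to compound 4, 7.8 percentage points apart, within the scatter of two such steps. Going by these compounds alone, this shows that in these two pairs methoxy in place of hydrogen goes with a higher number on either core, but it rests on only two pairs, says nothing about any other core, and, as a read-out at one concentration, gives neither a potency nor a reason for the step.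

The compounds shown leave open whether another group in that same place, such as an amine, a carboxylic acid or a fluorine, would move the number as methoxy does. They also leave open whether the step would hold with a longer chain than those of compound 2 and compound 4 joining the shared core to the rest of the molecule.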